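Anilide to cyclohexylamide on the shared core

The compounds below may be only part of what the source reports. "The series", "measured", "known", "first", "only" and "open" are said of these compounds alone.

Compound 2 `CC(C)(C)c1ccc(NC(=O)c2ncn(CC(=O)NCc3ccc4c(N)nccc4c3)n2)cc1` and compound 1 `Cc1ccc(NC(=O)c2ncn(CC(=O)NCc3ccc4c(N)nccc4c3)n2)cc1C` share one core and differ only on the amide-type nitrogen. In an assay on isolated protein for inhibition of protein arginine N-methyltransferase 7 (Homo sapiens), read by 33P incorporation (on this read-out higher numbers stand for weaker inhibition and lower numbers for stronger inhibition), compound 1 gives 69400 nM, and compound 2 gives 61500 nM; the step of a 1.1-fold lower number from compound 1 to compound 2 (0.05 log units; within the scatter) is within the scatter, so compound 2 stands with the lowest of the two numbers without being set apart from compound 1 in this assay.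

Compound 3 `Nc1nccc2cc(CNC(=O)Cn3cnc(C(=O)NC4CCCCC4)n3)ccc12` is not yet measured. The change from compound 2 is cyclohexyl in place of 4-(tert-butyl)phenyl on an amide-type nitrogen. Going by the values given here, no measured step bears directly on it: the only measured step, a 1.1-fold lower number from compound 1 to compound 2 (0.05 log units; within the scatter), swaps one aromatic group for another and was small. Going by these compounds, that step gives no sign that the group on this nitrogen moves the number much, but an aromatic ring leaving for a non-aromatic one is untested here, so the expectation is wide.

For compound 3 the estimate in this assay is 75000 nM, with a range from 25000 nM to 220000 nM. The expected step of a 1.2-fold higher number from compound 2 to compound 3 (0.09 log units; within the scatter) is none beyond the scatter, with the weak end of the series likely kept.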

Compound 3, half-maximal inhibitory concentration: "not active" (no number reported)
Compound 3 has no reported number here; the estimate stays without a comparison.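

Going by these compounds alone, compound 3 carries the entry "not active" without a number in this assay, so no step from compound 2 to compound 3 can be read. Nothing shown here accounts for this result. The compounds shown leave open how far cyclohexyl in place of 4-(tert-butyl)phenyl on the amide-type nitrogen shifts the inhibition.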